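From nitrothiophene to difluorophenyl on a shared core

The source may hold more compounds than are shown below. What is called first, only, known or untested is meant among the compounds shown, and "the series" means these compounds.

In a functional assay on MCF7 cells (Homo sapiens) for inhibition, read by MTT assay, with a stated time of 48 h, tested at 10 uM (on this read-out higher numbers stand for more inhibition of growth at the one concentration tested and lower numbers for less inhibition of growth), three compounds with a shared core have been measured. Compound 1 `Cc1oc2c([C@H]3CCN(C)C[C@H]3O)c(O)cc(O)c2c(=O)c1C(O)c1cccc(Cl)c1` gives 5%, compound 2 `Cc1oc2c([C@H]3CCN(C)C[C@H]3O)c(O)cc(O)c2c(=O)c1C(O)c1c(Cl)cccc1Cl` gives 33%, and compound 3 `Cc1oc2c([C@H]3CCN(C)C[C@H]3O)c(O)cc(O)c2c(=O)c1C(O)c1csc([N+](=O)[O-])c1` gives 20%, the second highest of the three. Compound 4 `Cc1oc2c([C@H]3CCN(C)C[C@H]3O)c(O)cc(O)c2c(=O)c1C(O)c1cc(F)cc(F)c1` has not yet been measured. It carries 3,5-difluorophenyl in place of 5-nitrothiophen-3-yl on a saturated chain carbon bound to an aromatic carbon and an oxygen on a saturated carbon.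

Three modest steps at this same place bear on the change: a number 28 percentage points higher from compound 1 to compound 2 (beyond the scatter), a number 15 percentage points higher from compound 1 to compound 3 (beyond the scatter) and a number 13 percentage points lower from compound 2 to compound 3 (beyond the scatter). None of them involves 3,5-difluorophenyl, so the guide is indirect. The nearest measured group is the 3-chlorophenyl of compound 1, which gives 5%, so a small fall is expected, smaller than a number 15 percentage points higher from compound 1 to compound 3 (beyond the scatter) and probably not beyond the scatter. The expected change is a number 6 percentage points lower from compound 3 to compound 4 (within the scatter). Compound 4 is estimated at 14%, with an expected range from 2% to 32%.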

Compound 4, percent growth inhibition at one concentration: 25%
Beside the measured number, compound 4's estimate is 11 percentage points below it; low and high end bracket the measured number.
By their numbers in this assay, from the lowest: compound 1; then compounds 3, 4 and 2 (each within the scatter of the next, the first and the last beyond it).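

In this assay, a number 5 percentage points higher from compound 3 to compound 4 (within the scatter) and a number 8 percentage points lower from compound 2 to compound 4 (within the scatter) show that 3,5-difluorophenyl on this saturated chain carbon cannot be told apart from either 5-nitrothiophen-3-yl or 2,6-dichlorophenyl. A ring of carbon only with no nitro group therefore matches the nitrothiophene here, and the chlorines of compound 2 are not needed to reach that range. The a number 20 percentage points higher from compound 1 to compound 4 (beyond the scatter) leaves compound 1 as the lowest of the four, beyond the scatter of each of the others, though nothing measured here accounts for that gap.

The compounds shown leave open how plain phenyl, 3-fluorophenyl or 3,5-dichlorophenyl would read at this carbon. They also leave open whether an amine or a carboxylic acid on the ring would be accepted here.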